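Adding a Second Fluoro: Cytotoxicity Expected for Compound 4

This account rests on a few compounds, and the source may have more. Where it says the series, first, only, none or still open, it means among the compounds named here.

Measured so far:
- compound 1 `N#Cc1cc2c(Oc3ccccc3OCCn3ccc(=O)[nH]c3=O)cc(F)cn2c1`: 40000 nM
- compound 2 `N#Cc1cc2c(Oc3ccc(F)cc3OCCn3ccc(=O)[nH]c3=O)cccn2c1`: 100000 nM
- compound 3 `N#Cc1cc2c(Oc3ccccc3OCCn3ccc(=O)[nH]c3=O)cccn2c1`: > 100000 nM

In an ADME assay on MT2 cells (Homo sapiens) for cytotoxicity, read by MTT assay (a lower number here means that less compound is tolerated, a higher number that more compound is tolerated), compound 2 gives the highest of the two numbers reported; the nearest is compound 1, which gives 40000 nM. The value of compound 3 in this assay is a limit of the assay, not a number.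

The unmeasured compound 4 `N#Cc1cc2c(Oc3ccc(F)cc3OCCn3ccc(=O)[nH]c3=O)cc(F)cn2c1` differs from compound 2 by fluoro in place of hydrogen on an aromatic carbon. The same position has been probed once in the opposite direction: an at least 2.5-fold higher number from compound 1 to compound 3 (0.39 log units; beyond the scatter), where the fluoro left and a hydrogen entered. The step of a number no lower from compound 2 to compound 3 (the limit leaves the size open) concerns a different fluoro and so does not speak to this position. Reversing the first step, placing fluoro where compound 2 has hydrogen, is expected to lower the number in this assay, and the step of a 2.9-fold lower number from compound 2 to compound 4 (0.46 log units; beyond the scatter) is therefore estimated as at least modest downward. Compound 4 is thus expected to give 35000 nM, within a range of 15000 nM to 80000 nM in this assay.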

Compound 4, half-maximal cytotoxic concentration: 50000 nM
Compound 4: the middle estimate sits 1.4-fold (0.15 log units) below what was measured, within the range that was stated.
By their numbers in this assay, from the lowest: compounds 1, 4 and 2 (each within the scatter of the next, the first and the last beyond it).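

In this assay compound 3 gives > 100000 nM, which is a limit, so the earlier step at this position had a number on only one side. The fluoro on the six-membered aromatic ring with 1 nitrogen now has a readable size on a core that already carries the other fluoro, a 2.0-fold lower number from compound 2 to compound 4 (0.30 log units; within the scatter), and the other fluoro, placed on the core of compound 1, gives a 1.3-fold higher number from compound 1 to compound 4 (0.10 log units; within the scatter), so neither step stands clear of the scatter. Whether each fluoro has the same size of step with and without the other stays unsettled: the same change on two cores in this assay, an at least 2.5-fold higher number (0.39 log units; beyond the scatter) from compound 1 to compound 3 and a 2.0-fold higher number (0.30 log units; within the scatter) from compound 4 to compound 2; the limit leaves it open whether they differ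

The second comparison is just as open: the same change on two cores in this assay, a number no lower (the limit leaves the size open) from compound 2 to compound 3 and a 1.3-fold lower number (0.10 log units; within the scatter) from compound 4 to compound 1; the limit leaves it open whether they differ The compounds shown also leave open whether another group at this position, such as chloro, methyl or an amine, would move the number beyond the scatter.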